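The source may report more compounds than this note shows. Statements on the series, on what has been measured and on what is new or still open speak of the compounds shown alone.

Measured compounds:
compound 1, `Cn1c(Cc2nn(C)c(=O)c3ccccc23)nnc1SCCCCCCCCCCCCCCCC(=O)Nc1ccc(Cl)cc1Cl`, this assay 7300 nM
compound 2, `CC(C)Oc1ccc(NC(=O)CSc2nnc(Cc3nn(C)c(=O)c4ccccc34)n2C)cc1`, this assay > 30000 nM
compound 3, `Cn1c(Cc2nn(C)c(=O)c3ccccc23)nnc1SCCCCCCCCCC(=O)Nc1ccc(Cl)cc1Cl`, this assay 2300 nM

In an assay on isolated protein (Mus musculus) for inhibition of IL15-IL15 receptor (Homo sapiens), read by resazurin assay, with stated times of 30 min and 2.5 days (a lower number here means a stronger inhibitor, a higher number a weaker inhibitor), compound 1 gives 7300 nM and compound 3 gives 2300 nM; both carry a long thioalkyl chain and a 2,4-dichlorophenyl amide. Compound 2 is different: it carries a short thioacetamide linker and a 4-isopropoxyphenyl amide, and in this assay compound 2 gives only a limit, > 30000 nM. Compound 2 therefore stands at the limit of > 30000 nM in this assay, at which 1 of the 3 values shown sits, and no number is known for it. Compounds 1 and 3 differ from compound 2 in both the chain and the aryl amide. Among the compounds with values here, no pair among the measured compounds isolates a single change, and no measured step is available.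

Compound 4, `Cn1c(Cc2nn(C)c(=O)c3ccccc23)nnc1SCC(=O)Nc1ccc(F)cc1F`, keeps the short linker of compound 2 and differs from it only in the amide aryl group: 2,4-difluorophenyl in place of 4-isopropoxyphenyl on an amide-type nitrogen. Within the data shown here, nothing among the measured compounds tells how this exchange alone acts. The working expectation is that compound 4 stays weak, near the limit of this assay, and the estimated step of a number no higher from compound 2 to compound 4 (the limit leaves the size open) is no larger than the scatter and may well end in another limit. Compound 4 is thus estimated at 30000 nM, with a range from 10000 nM to 100000 nM.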

Compound 4, half-maximal inhibitory concentration: "not active" (no number reported)
Compound 4 has no reported number here, and the estimate cannot be compared.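

No step can be read between compound 2 and compound 4: in this assay compound 4 is reported as not active, without a number, and compound 2 gives only a limit (> 30000 nM). Still open, on these data alone, is how the exchange of 4-isopropoxyphenyl for 2,4-difluorophenyl acts alone, and how chain length acts with the amide aryl group held fixed.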